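A few compounds are considered here, and "the series" means these few. Any claim that something is new, unique, unknown or untested is made for them only; others in the source may bear on it.

Working notes on the amide series.

Of the compounds shown here, three have been measured in a functional assay on the whole organism (strain albino) for inhibition, with Rattus norvegicus as the target, read by paw edema, with stated times of 30 min and 5 h, at a dose of 100 mg/kg by the oral route; a higher number here means more inhibition at the dose given (going by the name of the read-out), a lower number less inhibition. Compound 1, `COc1ccc(/C=C/C(=O)c2ccc(NC(=O)C(C)O[N+](=O)[O-])cc2)cc1`, carries a nitrooxypropanoyl amide on the shared core; in this assay compound 1 gives 35%. Compound 2, `CC(O[N+](=O)[O-])C(=O)Nc1ccc(C(=O)/C=C/c2ccco2)cc1`, keeps that amide and differs from compound 1 only in one place: furan-2-yl in place of 4-methoxyphenyl on a double-bonded chain carbon bound to a double-bonded chain carbon. Going by the values given here, the step of a number 14 percentage points higher from compound 1 to compound 2 (beyond the scatter) is the only measured instance of this change; in this assay compound 2 gives 49%.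

Compound 3, `COc1ccc(/C=C/C(=O)c2ccc(NC(=O)COCc3c(-c4ccccc4)no[n+]3[O-])cc2)cc1`, carries instead a furoxan-bearing ether chain on the amide; the difference between the core of compound 3 and that of compound 1 is not broken down here. In this assay compound 3 gives 49%, level with compound 2 at the digits printed.

Compound 4, `O=C(COCc1c(-c2ccccc2)no[n+]1[O-])Nc1ccc(C(=O)/C=C/c2ccco2)cc1`, has not been measured. It differs from compound 3 by the same change as compound 2 from compound 1: furan-2-yl in place of 4-methoxyphenyl on a double-bonded chain carbon bound to a double-bonded chain carbon. Beside the step from compound 1 to compound 2, the step from compound 3 to compound 4 is expected at a number 9 percentage points higher from compound 3 to compound 4 (within the scatter), somewhat smaller, because compound 3 gives 49%, already at the level where compound 2 stands, and only one instance of the change has been measured. Compound 4 is therefore expected to give 58% in this assay, with the estimate bounded by 45% and 70%.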

Compound 4, a percentage reported as inhibition, in the whole organism at one dose (the size of the read-out at that dose, not a potency): 49%
Estimate against measurement, compound 4: 9 percentage points above; the measured number falls inside the stated range.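

In this assay, furan-2-yl in place of 4-methoxyphenyl on the core with the furoxan-bearing ether chain gives no change at the digits printed from compound 3 to compound 4 (within the scatter) and so does not appear there as a step beyond the scatter. Set beside the step on the nitrooxypropanoyl amide, this reading cannot be separated from the earlier one: the same change on two cores in this assay, a number 14 percentage points higher (beyond the scatter) from compound 1 to compound 2 and no change at the digits printed (within the scatter) from compound 3 to compound 4, 14 percentage points apart, within the scatter of two such steps. Two instances of the change, read at one dose in one whole-organism assay, do not show that it carries from one core to another at full size, and they do not show that the amide chain governs its size either.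

The compounds shown leave open how other groups on a double-bonded chain carbon bound to a double-bonded chain carbon would read, such as thiophen-2-yl or a pyridine ring, which would show whether furan-2-yl and 4-methoxyphenyl are the only pair that reads this way on both cores. They also leave open whether the same change reads alike on a third amide chain, for instance one ending in an amine or a carboxylic acid, where a further instance could separate a real dependence on the chain from scatter.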